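The source may hold more compounds than are shown below. What is called first, only, known or untested is meant among the compounds shown, and "the series" means these compounds.

Measured so far in a physicochemical assay for lipophilicity, using the shake flask method, in phosphate buffer, measured as octanol-water partition, with a stated time of 30 min, at pH 7.4; on this read-out higher numbers stand for higher lipophilicity and lower numbers for lower lipophilicity:
- compound 1 `C[C@@H]1CC(=O)N(c2cnc(NCc3c(F)ccc4c3CCO4)n3cnnc23)C1`: 1.8
- compound 2 `Cc1ncc(-c2cnc(NCc3c(F)ccc4c3CCO4)c3cn[nH]c(=O)c23)n1C`: 1.9
- compound 3 `CN(c1ccccc1)c1cnc(NCc2c(F)ccc3c2CCO3)n2cnnc12`: 3.6

On this assay, compound 3 at 3.6 has the highest number of the three, and its gaps to the other two lie beyond the scatter. Compound 2 stands at 1.9 and compound 1 at 1.8.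

The next compound is compound 4 `C[C@H]1CC(=O)N(c2cnc(NCc3c(F)ccc4c3CCO4)n3cnnc23)C1`, not yet measured. From compound 3, 4-methyl-2-oxopyrrolidin-1-yl takes the place of methyl(phenyl)amino on an aromatic carbon of the shared core: 4-methyl-2-oxopyrrolidin-1-yl in place of methyl(phenyl)amino on an aromatic carbon.

Among the compounds with values here, one measured step bears on this change, and it exchanges the same two groups at the same place in the opposite sense. That step is large: a number 1.80 log units higher from compound 1 to compound 3 (beyond the scatter). Within the data shown here, compound 2 differs from compound 3 in more than one place and gives no step. No measurement here tests whether the sense of the defined stereocentre in the entering group matters. Read in reverse, the step of a number 1.80 log units higher from compound 1 to compound 3 (beyond the scatter) points to a large fall of similar size. The expected step is a number 1.80 log units lower from compound 3 to compound 4 (beyond the scatter), beyond the scatter. For compound 4 the estimate is 1.8, with an expected range from 1.5 to 2.1.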

Compound 4, distribution coefficient: 1.8
Estimate against measurement, compound 4: no gap at the digits printed; measured number inside the range.
By their numbers in this assay, from the lowest: compounds 1, 4 and 2 (each within the scatter of the next); then compound 3.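

In this assay, the large size of this exchange on the aromatic carbon holds for both drawn forms of 4-methyl-2-oxopyrrolidin-1-yl: the new step is a number 1.80 log units lower from compound 3 to compound 4 (beyond the scatter), of the same size as the earlier step, a number 1.80 log units higher from compound 1 to compound 3 (beyond the scatter). The sense of the stereocentre at the saturated ring carbon leaves no mark on this read-out, with no change at the digits printed from compound 1 to compound 4 (within the scatter). That comparison carries no other structural change, so it speaks to configuration alone, and it rests on a single pair: the fact that compounds 1 and 4 differ only in the configuration as drawn

Which feature of the exchange carries the large step stays open, as methyl(phenyl)amino and 4-methyl-2-oxopyrrolidin-1-yl differ at once in their ring, in the carbonyl and in the carbon-only aromatic ring; a plain dimethylamino group or a morpholine at this aromatic carbon would help to separate these features. Within the data shown here, also open is whether configuration still shows no step in this assay when the methyl of 4-methyl-2-oxopyrrolidin-1-yl gives way to a longer chain such as propyl.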